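A catechol-ether amide where the anilide ring gives way

The compounds below may be only part of what the source reports. "The series", "measured", "known", "first", "only" and "open" are said of these compounds alone.

Three compounds share one core, a catechol ether carrying an amide. Compound 1 `COc1ccc(C(=O)Nc2ccccc2C(F)(F)F)cc1OC1CCCC1` gives 3100 nM in an assay on isolated protein for inhibition of phosphodiesterase 4A (Sus scrofa); a higher number here means a weaker inhibitor, a lower number a stronger inhibitor. Compound 2 `COc1ccc(C(=O)Nc2ccccc2SC)cc1OC1CCCC1` gives 1200 nM, and compound 3 `COc1ccc(C(=O)Nc2c(F)cnc(F)c2F)cc1OC1CCCC1` gives 85 nM. Compound 2 thus stands second highest of the three: the step of a 2.6-fold lower number from compound 1 to compound 2 (0.41 log units; beyond the scatter) separates it from compound 1, while compound 3 sits a long way lower.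

Compound 4 `COc1ccc(C(=O)NC2(C)C=C(C)ON2)cc1OC1CCCC1` has not been measured. Its change from compound 2 is a group of 7 heavy atoms (5 carbon, 1 nitrogen, 1 oxygen; one five-membered non-aromatic ring with 2 hetero atoms) in place of a group of 8 heavy atoms (7 carbon, 1 sulfur; one six-membered aromatic ring of carbon only), on an amide-type nitrogen. For the measured compounds named here, the only measured step, a 2.6-fold lower number from compound 1 to compound 2 (0.41 log units; beyond the scatter), swaps one group on the aromatic ring for another and so says little about removing that ring altogether; compound 3 shows that a different aromatic ring can lower the number strongly, but no measured pair tests a non-aromatic ring on the amide nitrogen. With the aromatic ring gone, a weaker inhibitor seems the more likely outcome, and the expected step is a 3.3-fold higher number from compound 2 to compound 4 (0.52 log units; beyond the scatter). Compound 4 is therefore estimated at 4000 nM, within a range from 1000 nM to 15000 nM.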

Compound 4, half-maximal inhibitory concentration: 450 nM
Compound 4: middle estimate off by 8.9-fold (0.95 log units), on the high side; measured number outside the range, below it.
By their numbers in this assay, from the lowest: compound 3; then compound 4; then compound 2; then compound 1.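

Removing the aromatic ring from the amide nitrogen does not cost binding strength in this assay for this pair: replacing the 2-(methylsulfanyl)phenyl group with a five-membered non-aromatic ring gives a 2.7-fold lower number from compound 2 to compound 4 (0.43 log units; beyond the scatter) and so moves the number down, not up. Until now, every group measured on this nitrogen had been an aromatic ring, so a non-aromatic ring can clearly work here as well. No measured data on hand explain the lower number.

On these data alone, compound 3 at 85 nM still gives a lower number than compound 4 at 450 nM, and it remains open whether any non-aromatic ring could close that gap. The compounds shown also leave open what a plain cyclohexyl group or a piperidine ring on the amide nitrogen would give.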